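The source may hold more compounds than are shown below. What is called first, only, known or untested is meant among the compounds shown, and "the series" means these compounds.

Measured so far:
Compound 1 `CN1CCCN(Cc2ccc(-c3ccc(N4CCN(C)CC4)cc3)cc2)CC1` gives 1300 nM in an assay on isolated protein for inhibition of choline kinase alpha (Homo sapiens), with a stated time of 30 min; a lower number here means a stronger inhibitor, a higher number a weaker inhibitor.
Compound 2 `CN1CCCN(Cc2ccc3ncccc3c2)CC1` gives 3900 nM in this assay.
Compound 3 `CN1CCCN(Cc2ccc(-c3ccc(CN4CCCN(C)CC4)c(F)c3F)cc2)CC1` gives 233 nM in this assay.

Among these three numbers compound 1 stands second highest: compound 2 sits higher, beyond the scatter, and compound 3 sits lowest, also beyond the scatter. Compound 4 `CN1CCCN(Cc2ccc(-c3ccc(CN4CCCN(C)CC4)cc3)cc2)CC1` has not yet been measured. It differs from compound 1 in one place, ((4-methyl-1,4-diazepan-1-yl)methyl in place of 4-methylpiperazin-1-yl on an aromatic carbon). For the measured compounds named here, no measured pair shows this exact change, so the size of the step rests on the neighbouring compounds alone; compound 3, which carries the same entering group, gives 233 nM. On that basis compound 4 is expected to give a lower number than compound 1, with the step of a 3.3-fold lower number from compound 1 to compound 4 (0.51 log units; beyond the scatter) judged beyond the scatter. Compound 4 is therefore estimated at 400 nM, within a range from 150 nM to 1200 nM.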

Compound 4, half-maximal inhibitory concentration: 457 nM
The estimate for compound 4 lay 1.1-fold (0.06 log units) below the measured number; the range from low to high includes it.
By their numbers in this assay, from the lowest: compounds 3 and 4 (each within the scatter of the next); then compound 1; then compound 2.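

For the compounds shown here, on an aromatic carbon para to a large group, (4-methyl-1,4-diazepan-1-yl)methyl in place of 4-methylpiperazin-1-yl gives a 2.8-fold lower number from compound 1 to compound 4 (0.45 log units; beyond the scatter) in this assay, the first direct reading of this change. The step is modest but beyond the scatter, so this exchange alone shifts the number. No measurement shown bears on why the number falls. The compounds leave open whether the added carbon or the seven-membered ring accounts for the step. A (4-methylpiperazin-1-yl)methyl group or a (dimethylamino)methyl group here would help to separate the two.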